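Adding fluoro to the phenyl of compound 3: expected step

The source may hold more compounds than are shown below. What is called first, only, known or untested is meant among the compounds shown, and "the series" means these compounds.

In a functional assay on B16 cells (Mus musculus) for cytotoxicity, read by CCK-8 assay, with a stated time of 24 h (on this read-out lower numbers stand for stronger inhibition and higher numbers for weaker inhibition), compound 1 (`COc1ccc(-c2nc(N)c(Oc3ccccc3OC)c(Cl)n2)cc1`) gives 47800 nM, compound 2 (`COc1ccccc1Oc1c(N)nc(-c2cccc(I)c2)nc1Cl`) gives 27600 nM and compound 3 (`COc1ccccc1Oc1c(N)nc(-c2ccccc2)nc1OCCO`) gives 31100 nM. These three numbers lie within the scatter of one another, so compound 3 has no separate rank in the set and serves as a plain reference point for the next step.

Compound 4 (`COc1ccccc1Oc1c(N)nc(-c2ccc(F)cc2)nc1OCCO`) is compound 3 with fluoro in place of hydrogen on an aromatic carbon, read one bond further out as phenyl to 4-fluorophenyl: fluoro in place of hydrogen on an aromatic carbon.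

Among the measured compounds shown here, no measured step adds fluoro. For the measured compounds named here, the nearest evidence is the only measured step, which also changes the group on that ring position of the shared core: a 1.7-fold lower number from compound 1 to compound 2 (0.24 log units; within the scatter). That is a much larger swap of substituents than the one here, yet it stays within the scatter. Compound 3 also differs from compound 1 and compound 2 elsewhere on the core, so this step transfers only loosely.

On that basis, no shift beyond the scatter is expected in this assay. The expected step is a 1.0-fold lower number from compound 3 to compound 4 (0.02 log units; within the scatter). For compound 4 the estimated value is 30000 nM, with a range of 16000 nM to 55000 nM.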

Compound 4, half-maximal inhibitory concentration: 30100 nM
Estimate against measurement, compound 4: 1.0-fold (0.00 log units) below, and the stated range covers the measured number.
By their numbers in this assay, from the lowest: compounds 2, 4, 3 and 1 (each within the scatter of the next).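

In this assay, fluoro in place of hydrogen on an aromatic carbon, para to a large group, gives a 1.0-fold lower number from compound 3 to compound 4 (0.01 log units; within the scatter), which is the series' first single-place reading on the core of compound 3. The earlier step between compound 1 and compound 2 compares two other aryl groups on a different core, so it could only suggest how this position behaves. Here, phenyl and 4-fluorophenyl cannot be told apart in this assay, and no further measurement bears on the reading of this step.

As far as these compounds go, a single fluoro says little about the position as a whole, so it remains open whether a larger or differently built group at the same place, such as an amine, a carboxylic acid or a longer chain, would give a step beyond the scatter. From the compounds shown here alone, it also remains open whether the same fluoro change would read the same way on the core of compound 1 or compound 2, or in any assay other than this assay.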